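The compounds below may be only part of what the source reports. "The series", "measured", "known", "first", "only" and "open" are said of these compounds alone.

Measured so far:
compound 1, `Cn1nc(C(N)=O)cc1-c1ccc(OC(=O)NC2CCCCC2)cc1`, 209 nM
compound 2, `CCOC(=O)c1cc(-c2ccc(OC(=O)NC3CCCCC3)cc2)nn1C`, 316 nM

Both compounds were tested in an assay on isolated protein for inhibition of Fatty-acid amide hydrolase 1 (Homo sapiens), read by fluorescence, with a stated time of 30 min; on this read-out lower numbers stand for stronger inhibition and higher numbers for weaker inhibition. Compound 1 gives 209 nM, and compound 2 gives 316 nM. These two numbers lie within the usual scatter of each other, so neither compound can be called the stronger inhibitor; compound 2 simply stands at one of two closely spaced values.

Compound 3, `CCOC(=O)c1cc(-c2ccc(OC(=O)NC3CCCCC3)cc2)nn1-c1ccc(Cl)cc1`, has not yet been measured. It differs from compound 2 by 4-chlorophenyl in place of methyl on an aromatic nitrogen. For the measured compounds named here, no pair of measured compounds shows what such a change does here, so there is no step to lean on. The expectation for compound 3 is therefore a number that stays within the scatter of compound 2, with a wide range to allow for either direction. Compound 3 is estimated at 250 nM, between 60 nM and 1000 nM, which is expected to correspond to a step of a 1.3-fold lower number from compound 2 to compound 3 (0.10 log units; within the scatter).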

Compound 3, half-maximal inhibitory concentration: 586 nM
Compound 3: middle estimate off by 2.3-fold (0.37 log units), on the low side, and the stated range covers the measured number.
By their numbers in this assay, from the lowest: compounds 1, 2 and 3 (each within the scatter of the next, the first and the last beyond it).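

Compound 1 and compound 2 both carry methyl on the aromatic nitrogen, so they could say nothing about this position. Putting 4-chlorophenyl in place of methyl there gives a 1.9-fold higher number from compound 2 to compound 3 (0.27 log units; within the scatter) in this assay, so a group with a whole six-membered aromatic ring in place of a single carbon leaves the reading within the scatter. This holds for this one pair, with the ethoxycarbonyl group in place, and nothing available explains the result.

As far as these compounds go, whether a benzyl group, a smaller ring such as cyclopropyl or a chain ending in an amine or a carboxylic acid would read differently on that nitrogen remains open. Also open, from the compounds shown here alone, is whether 4-chlorophenyl would give a similar step on a compound carrying the primary amide of compound 1.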